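Chain shortening at the sulfonyl group: working notes

A few compounds are considered here, and "the series" means these few. Any claim that something is new, unique, unknown or untested is made for them only; others in the source may bear on it.

Measured so far:
compound 1, `CCCCS(=O)(=O)c1ccc(O)c(C(=O)Nc2ccc(Br)cc2)c1`: in a physicochemical assay for lipophilicity (a higher number here means a more lipophilic compound, a lower number a more polar compound), compound 1 gives 4.12
compound 2, `CCCCCCCCCCS(=O)(=O)c1ccc(O)c(C(=O)Nc2ccc(Br)cc2)c1`: in this assay compound 2 gives 7.36
compound 3, `CCCCCCCCCCCCS(=O)(=O)c1ccc(O)c(C(=O)Nc2ccc(C(F)(F)F)cc2)c1`: in this assay compound 3 gives 8.46

Compound 3 stands highest of the three, with compound 2 nearest and compound 1 furthest. The pair compound 2 and compound 1 carries one change, (hydrogen in place of hexyl on a saturated chain carbon, four bonds along the chain from a sulfonyl sulfur), and it made a number 3.24 log units lower from compound 2 to compound 1 (beyond the scatter).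

Not yet measured is compound 4, `CCCCCCS(=O)(=O)c1ccc(O)c(C(=O)Nc2ccc(C(F)(F)F)cc2)c1`. It differs from compound 3 by hydrogen in place of hexyl on a saturated chain carbon, six bonds along the chain from a sulfonyl sulfur. The group that leaves and the group that enters are the same as in the step from compound 2 to compound 1, but the place is not the same word for word: there the carbon was four bonds along the chain from the sulfonyl sulfur, here it is six bonds along. It is therefore the same kind of change, not the same. The cores of compound 2 and compound 3 also differ, and that difference between the two cores is not broken down here.

For the measured compounds named here, on the same kind of change, the only example is a number 3.24 log units lower from compound 2 to compound 1 (beyond the scatter), and the expectation for compound 4 rests on that step carried over to compound 3. The step from compound 3 to compound 4 is expected to be a number 3.26 log units lower from compound 3 to compound 4 (beyond the scatter). Compound 4 is thus estimated at 5.2, with the range 4.6 to 5.8.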

Compound 4, partition coefficient: 5.22
Estimate against measurement, compound 4: 0.02 log units below; the range from low to high includes it.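

In this assay, hydrogen in place of hexyl gave a number 3.24 log units lower from compound 3 to compound 4 (beyond the scatter) on the core bearing trifluoromethyl, and the same exchange gave a number 3.24 log units lower from compound 2 to compound 1 (beyond the scatter) on the core bearing bromine, so the two steps print at the same size even though the carbon carrying the change lies six bonds along the chain from the sulfonyl sulfur in one case and four bonds along in the other. Within this series the change therefore carried from one core to the other without a visible shift in size, but this rests on only two examples, one per core, and gives no general rule for other cores, other chain lengths or other exchanges. Nothing shown explains why the two steps match, and no supporting measurement bears on the result.

The compounds shown include no pair that differs in the core alone, so what the core contributes on its own remains open, and the agreement of the two steps cannot be split into a core part and a chain part. For the compounds shown here, also open is whether the step would hold for a chain longer than the one in compound 3, or where an amine or a carboxylic acid enters in place of hydrogen.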